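The source may report more compounds than this note shows. Statements on the series, on what has been measured and on what is new or still open speak of the compounds shown alone.

Compound 1 `Nc1sccc1C(=O)c1ccc(Cl)cc1`: 40%
Compound 2 `Nc1sc(-c2ccccc2)cc1C(=O)c1ccc(Cl)cc1`: 16%
Compound 3 `Nc1sc(-c2cncnc2)cc1C(=O)c1ccc(Cl)cc1`: 4%

All three were measured in an assay on CHO cells for positive allosteric modulation of adenosine receptor A1 (Homo sapiens), read by ERK phosphorylation, tested at 10 uM; a lower number here means a stronger effect, a higher number a weaker effect of the compound at the concentration tested. Compound 2 stands second highest of the three numbers: its nearest neighbour is compound 3, reached by a number 12 percentage points lower from compound 2 to compound 3 (beyond the scatter), and its furthest is compound 1, from which compound 2 is reached by a number 24 percentage points lower from compound 1 to compound 2 (beyond the scatter). Compound 4 `Nc1sc(-c2ccc(C(=O)O)cc2)cc1C(=O)c1ccc(Cl)cc1` differs from compound 2 by one change: carboxy in place of hydrogen on an aromatic carbon The carboxy sits on the six-membered aromatic ring of carbon only, para to a large group. Within the data shown here, the step that bears on this is the other alteration of that same ring, a number 12 percentage points lower from compound 2 to compound 3 (beyond the scatter), a modest lowering; no measured step adds a carboxy group. A small lowering or none beyond the scatter is therefore expected in this assay, as a number 4 percentage points lower from compound 2 to compound 4 (within the scatter). Compound 4 is thus estimated at 12%, within 2% to 28%.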

Compound 4, a percentage reported as activity, at one concentration (the size of the read-out at that concentration, not a potency): 29%
Beside the measured number, compound 4's estimate is 17 percentage points below it; the whole stated range lies below it.
By their numbers in this assay, from the lowest: compound 3; then compound 2; then compound 4; then compound 1.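

In this assay the carboxy change runs opposite to the ring change that gave compound 3: the result is a number 13 percentage points higher from compound 2 to compound 4 (beyond the scatter) and marks a weaker effect. This position on the carbon-only ring therefore responds to what is placed there, and a change at it can weaken the effect as well as strengthen it. Nothing measured here explains the rise.

As far as these compounds go, whether the carboxy group itself matters, or simply any added group, stays open. A methyl ester, an amide or a hydroxyl group in the same place could help separate these possibilities.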